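A Shorter Chain and a Hydroxypiperidine on the Shared Core

This account rests on a few compounds, and the source may have more. Where it says the series, first, only, none or still open, it means among the compounds named here.

Within the data shown here, compound 2 `CN1CCN(CCCCn2c3c(c4ccccc42)C(=O)c2c[n+]([O-])c4ccccc4c2C3=O)CC1` is the stronger of the two compounds measured so far in a functional assay on MCF7 cells (Homo sapiens) for cytotoxicity, read by MTT assay, with a stated time of 72 h; a higher number here means a weaker inhibitor, a lower number a stronger inhibitor: compound 2 gives 100 nM, while compound 1 `O=C1c2c[n+]([O-])c3ccccc3c2C(=O)c2c1c1ccccc1n2Cc1cn([C@H]2O[C@H](CO)[C@@H](O)[C@H]2O)nn1` gives 1490 nM, a gap well beyond the usual scatter of repeated measurements. The next compound, compound 3 `O=C1c2c[n+]([O-])c3ccccc3c2C(=O)c2c1c1ccccc1n2CCCN1CCC(O)CC1`, keeps the shared core of compound 2 and changes only one part of the structure: 4-hydroxypiperidin-1-yl in place of (4-methylpiperazin-1-yl)methyl on a saturated chain carbon, three bonds along the chain from an aromatic nitrogen. Among the measured compounds shown here, no pair of measured compounds differs in exactly this way, so there is no measured step to lean on. Given the value of compound 2 at 100 nM, compound 3 is expected to remain in the same general region but to come out somewhat weaker, with an anticipated step of a 2.5-fold higher number from compound 2 to compound 3 (0.40 log units; beyond the scatter). The estimate for compound 3 in this assay is 250 nM, expected to fall between 80 nM and 800 nM.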

Compound 3, half-maximal inhibitory concentration: 190 nM
The estimate for compound 3 lay 1.3-fold (0.12 log units) above the measured number; the measured number falls inside the stated range.
By their numbers in this assay, from the lowest: compounds 2 and 3 (each within the scatter of the next); then compound 1.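

In this assay, the first step measured at this position, a 1.9-fold higher number from compound 2 to compound 3 (0.28 log units; within the scatter), leaves compound 2 and compound 3 indistinguishable, so the ring on the chain can go from 4-methylpiperazine to 4-hydroxypiperidine without a change that can be read. The same difference, read as 4-(4-methylpiperazin-1-yl)butyl to 3-(4-hydroxypiperidin-1-yl)propyl, alters the chain and the ring together, so this single step cannot separate the two. Nothing at hand offers an explanation for this result.

From the compounds shown here alone, it remains open whether a 4-(4-hydroxypiperidin-1-yl)butyl chain or a 3-(4-methylpiperazin-1-yl)propyl chain on the shared core would give a similar number. Going by these compounds, it is equally open how a morpholine ring or a simple dimethylamino group at the end of the chain would read in this assay.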